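The compounds below may be only part of what the source reports. "The series", "measured", "known", "first", "only" and "open" are said of these compounds alone.

Three esters sharing one core are at issue here, each with a chain ending in a nitrooxy group: compound 1 `COc1cc(/C=C/C(=O)OCCCCCO[N+](=O)[O-])ccc1O`, compound 2 `COc1cc(/C=C/C(=O)OCCCO[N+](=O)[O-])ccc1O` and compound 3 `COc1cc(/C=C/C(=O)OC/C=C/CO[N+](=O)[O-])ccc1O`. In a functional assay on Calu-1 cells (Homo sapiens) for cytotoxicity, read by resazurin assay, with a stated time of 72 h (a higher number here means a weaker inhibitor, a lower number a stronger inhibitor), compound 1 gives 26300 nM. Compound 2 is recorded as > 50000 nM, which is a limit of the assay and not a number. Its standing is therefore known only as that limit.

Compound 3 differs from compound 2 by a group of 7 heavy atoms (3 carbon, 1 nitrogen, 3 oxygen; no ring) in place of a group of 6 heavy atoms (2 carbon, 1 nitrogen, 3 oxygen; no ring), on a saturated chain carbon bound to an oxygen next to a carbonyl group. The group that leaves is 2-(nitrooxy)ethyl, and the group that enters has no common name. The change lies on a saturated chain carbon bound to an oxygen next to a carbonyl group.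

Among the measured compounds shown here, only one measured step bears on this: an at least 1.9-fold higher number from compound 1 to compound 2 (0.27 log units; that floor lies within the scatter). That figure is a floor lying within the scatter, and it involves no added double bond, so it offers only weak guidance. A small move towards a lower number in this assay is expected, perhaps none beyond the scatter. The estimated step is an at least 1.3-fold lower number from compound 2 to compound 3 (0.11 log units; that floor lies within the scatter). For compound 3 the estimated value is 38000 nM, with an expected range from 18000 nM to 70000 nM.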

Compound 3, half-maximal inhibitory concentration: 2480 nM
Estimate against measurement, compound 3: 15-fold (1.19 log units) above, outside the stated range (below it).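

In this assay the change on a saturated chain carbon bound to an oxygen next to a carbonyl group brings an at least 20-fold lower number from compound 2 to compound 3 (1.30 log units; beyond the scatter) and so shows that this place can respond strongly to a single change. The earlier step (an at least 1.9-fold higher number from compound 1 to compound 2 (0.27 log units; that floor lies within the scatter)) went no further than the scatter and involved no added double bond, whereas the entering group here carries a second double bond outside aromatic rings and its step lies beyond the scatter. As far as these compounds go, the true size of the step from the lower limit of the assay remains unknown because the value for compound 2 is a limit and not a number: the limit of > 50000 nM in this assay, at which 1 of the 3 values shown sits.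

The compounds shown leave open whether the added double bond or the added chain carbon goes with this step, since the entering group differs from 2-(nitrooxy)ethyl in both, and a saturated 4-(nitrooxy)butyl group at this place would bear directly on that question. They also leave open whether the nitrooxy group matters to the result, which a chain ending in a hydroxyl group instead would address.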